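From 2,4-dimethylphenyl to phenyl in compound 1

This account rests on a few compounds, and the source may have more. Where it says the series, first, only, none or still open, it means among the compounds named here.

Measured so far in a functional assay on MCF7 cells (Homo sapiens) for inhibition, read by MTT assay, with a stated time of 72 h; on this read-out lower numbers stand for stronger inhibition and higher numbers for weaker inhibition:
Compound 1 `COc1cc2c(Oc3ccc(NC(=O)c4nn(-c5ccc(C)cc5C)cc(C)c4=O)cc3)ccnc2cc1OCCCCCCC(=O)NO` gives 2430 nM
Compound 2 `COc1cc2c(Oc3ccc(NC(=O)c4nn(-c5ccccc5F)cc(C)c4=O)cc3F)ccnc2cc1OCCCCCC(=O)NO` gives 2320 nM
Compound 3 `COc1cc2c(Oc3ccc(NC(=O)c4nn(-c5ccccc5C)ccc4=O)cc3)ccnc2cc1OCCCCCC(=O)NO` gives 4360 nM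

Compound 1 at 2430 nM lies within the usual scatter of both other compounds. Compound 4 `COc1cc2c(Oc3ccc(NC(=O)c4nn(-c5ccccc5)cc(C)c4=O)cc3)ccnc2cc1OCCCCCCC(=O)NO` has phenyl in place of 2,4-dimethylphenyl on an aromatic nitrogen and is still unmeasured. For the measured compounds named here, no two measured compounds differ in one place only, so this change has no direct precedent. The groups on that nitrogen vary across the measured set, although these compounds also differ elsewhere, and compound 2 at 2320 nM and compound 3 at 4360 nM remain within scatter of compound 1. No shift beyond the scatter is therefore expected in this assay for this change. The estimated 1.2-fold higher number from compound 1 to compound 4 (0.06 log units; within the scatter) is small. Compound 4 is estimated at 2800 nM with an expected range from 1200 nM to 6500 nM as its likely span.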

Compound 4, half-maximal inhibitory concentration: 1610 nM
Beside the measured number, compound 4's estimate is 1.7-fold (0.24 log units) above it; measured number inside the range.
By their numbers in this assay, from the lowest: compounds 4, 2, 1 and 3 (each within the scatter of the next, the first and the last beyond it).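

this assay now has its first direct comparison at this position, with only the group on the aromatic nitrogen changing: a 1.5-fold lower number from compound 1 to compound 4 (0.18 log units; within the scatter). Both methyl groups of 2,4-dimethylphenyl can therefore be removed, leaving phenyl, without a shift beyond the scatter. Nothing available here explains this small step.

Going by these compounds, whether a pyridyl ring or a benzyl group on that nitrogen would shift the number beyond the scatter remains open. Also open, on these data alone, is whether either methyl group alone matters.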